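This account rests on a few compounds, and the source may have more. Where it says the series, first, only, none or still open, it means among the compounds named here.

In a functional assay on HepG2 cells (Homo sapiens) for inhibition, read by MTT assay, with a stated time of 48 h (a lower number here means a stronger inhibitor, a higher number a weaker inhibitor), two compounds have been measured so far. Compound 1 `COc1ccc(N(C)c2nc(C)nc3ccccc23)cc1OCCC[Se]C#N` gives 1040 nM, and compound 2 `COc1ccc(N(C)c2nc(C)nc3ccccc23)cc1OCCCCCC[Se]C#N` gives 4890 nM, the higher of the two numbers and so the weaker inhibitor. Compound 3 `COc1ccc(N(C)c2nc(C)nc3ccccc23)cc1C(=O)OCCC[Se]C#N` is still unmeasured. It differs from compound 2 by a group of 9 heavy atoms (5 carbon, 1 nitrogen, 2 oxygen, 1 selenium; no ring) in place of a group of 10 heavy atoms (7 carbon, 1 nitrogen, 1 oxygen, 1 selenium; no ring), on an aromatic carbon, on an aromatic carbon, ortho to a methoxy group: the entering group has a carbonyl in its link to the ring and ends in the shorter chain of compound 1. Going by the values given here, the only measured step that bears on this is a 4.7-fold higher number from compound 1 to compound 2 (0.67 log units; beyond the scatter), a modest change that goes with the longer chain. Part of that step is expected to reverse in compound 3, although no measured compound shows the effect of the carbonyl link, so the range stays wide. The expected change is a 2.7-fold lower number from compound 2 to compound 3 (0.43 log units; beyond the scatter), towards a lower number. Compound 3 is estimated at 1800 nM, within a range of 600 nM to 5500 nM.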

Compound 3, half-maximal inhibitory concentration: 340 nM
The estimate for compound 3 lay 5.3-fold (0.72 log units) above the measured number; measured number outside the range, below it.
By their numbers in this assay, from the lowest: compound 3; then compound 1; then compound 2.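

At this aromatic carbon, ortho to a methoxy group, the link to the ring matters on its own in this assay: with the shorter chain kept, the entering group with a carbonyl in its link gives a 3.1-fold lower number from compound 1 to compound 3 (0.49 log units; beyond the scatter) and so outperforms the plain oxygen link. The larger step, a 14-fold lower number from compound 2 to compound 3 (1.16 log units; beyond the scatter), combines that carbonyl link with the shorter chain, so it changes two features at once and its size cannot be assigned to either one alone. No supporting evidence bears on either difference.

Still open, going by these compounds, is whether the longer chain of compound 2 would cost as much on the carbonyl link as it does on the oxygen link. Also open, on these data alone, is how an amide link or a carboxylic acid at this aromatic carbon would compare.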